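The source may hold more compounds than are shown below. What is called first, only, known or untested is meant among the compounds shown, and "the series" means these compounds.

Of the compounds shown here, three have been measured in a functional assay on SGC-7901 cells (Homo sapiens) for antiproliferative activity, read by MTT assay, with a stated time of 48 h; a higher number here means a weaker inhibitor, a lower number a stronger inhibitor. Compound 1 `O=C(/C=C/c1ccc(Oc2cc(=O)oc3ccccc23)cc1)/C=C/c1cccnc1` gives 17400 nM, compound 2 `COc1ccc(/C=C/C(=O)/C=C/c2ccc(Oc3cc(=O)oc4ccccc34)cc2)cc1OC` gives 49400 nM, and compound 3 `COc1cc(OC)c2c(=O)c(OCCCCOc3ccccc3/C=C/C(=O)/C=C/c3ccco3)c(-c3cc(OC)c(OC)c(OC)c3)oc2c1` gives 8980 nM. Compound 3 holds the lowest of the three numbers; its nearest neighbour is compound 1, whose number lies within the scatter of it, while compound 2 lies beyond the scatter above it. Compound 4 `COc1cc(OC)c2c(=O)c(OCCCCOc3ccccc3/C=C/C(=O)/C=C/c3cccc([N+](=O)[O-])c3)c(-c3cc(OC)c(OC)c(OC)c3)oc2c1` is derived from compound 3 by a single change, (3-nitrophenyl in place of furan-2-yl on a double-bonded chain carbon bound to a double-bonded chain carbon). For the measured compounds named here, only one measured step speaks to swapping an aryl group at such a position: a 2.8-fold higher number from compound 1 to compound 2 (0.45 log units; beyond the scatter), a modest shift. That step concerned different groups, so it fixes neither the size nor the direction for compound 4 with confidence, but it suggests any move in this assay should stay modest. Compound 4 is therefore expected to change by a 1.1-fold higher number from compound 3 to compound 4 (0.05 log units; within the scatter), and its estimated value in this assay is 10000 nM, likely between 3500 nM and 28000 nM.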

Compound 4, half-maximal inhibitory concentration: 4030 nM
The estimate for compound 4 lay 2.5-fold (0.39 log units) above the measured number, and the stated range covers the measured number.
By their numbers in this assay, from the lowest: compound 4; then compounds 3 and 1 (each within the scatter of the next); then compound 2.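

In this assay, 3-nitrophenyl in place of furan-2-yl on a double-bonded chain carbon bound to a double-bonded chain carbon gives a 2.2-fold lower number from compound 3 to compound 4 (0.35 log units; beyond the scatter) and so shows that an aryl exchange at this place can lower the number, with a phenyl ring bearing a nitro group in the entering position. For the compounds shown here, the only earlier step ran the other way, a 2.8-fold higher number from compound 1 to compound 2 (0.45 log units; beyond the scatter) on a different core and with different groups, so the direction at this place depends on the groups or the core involved, and the two steps cannot be told apart further. Nothing available here explains the shift. On these data alone, what stays open is whether the phenyl ring or the nitro group carries the step, which an unsubstituted phenyl or a 3-aminophenyl group at the same place would separate. As far as these compounds go, it is also open whether furan-2-yl and 3-nitrophenyl would differ in the same direction on the core of compound 1.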